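Adding a methoxy to compound 3

The compounds below may be only part of what the source reports. "The series", "measured", "known", "first", "only" and "open" are said of these compounds alone.

In a functional assay on MOLT-4 cells (Homo sapiens) for antiproliferative activity, read by cell counting, with a stated time of 2 days (on this read-out higher numbers stand for weaker inhibition and lower numbers for stronger inhibition), compound 1 (`COc1ccc(Nc2nc(N)c(C(=O)c3ccccc3)s2)cc1`) gives 230 nM. Compound 3 (`Nc1nc(Nc2ccc(F)cc2)sc1C(=O)c1ccccc1`) gives > 10000 nM, which is a limit and not a number. Compound 2 (`COc1ccc(C(=O)c2sc(Nc3ccc(Cl)cc3)nc2N)cc1`) gives > 10000 nM, which is also a limit. Compound 3 therefore stands at the limit of > 10000 nM in this assay, at which 2 of the 3 values shown sit, with no measured floor beneath it to show how far it lies from the assay's range.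

Compound 4 (`COc1ccc(C(=O)c2sc(Nc3ccc(F)cc3)nc2N)cc1`) follows from compound 3 by methoxy in place of hydrogen on an aromatic carbon, phenyl becoming 4-methoxyphenyl.

Going by the values given here, the one measured step is large: an at least 43-fold higher number from compound 1 to compound 3 (1.63 log units; beyond the scatter). It shows that methoxy and fluoro can separate two compounds widely, but it is an exchange at a different place from the one at issue here, so it bears only indirectly. The closer guide is compound 2, which already carries the 4-methoxyphenyl group and still reads > 10000 nM, a limit.

No recovery of activity is therefore expected in this assay, and no step beyond the scatter is anticipated. The expected change is a number no higher from compound 3 to compound 4 (the limit leaves the size open). A report of the limit alone is the likeliest outcome. For compound 4 the estimate is 10000 nM, with an expected range from 3000 nM to 30000 nM.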

Compound 4, half-maximal inhibitory concentration: > 10000 nM
Compound 4 was reported as a limit; the forecaster's own chance of this, stated with the estimate: 70%; the middle value sits exactly at the limit.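

In this assay compound 4 gives > 10000 nM, a limit and not a number. No new step can be read from compound 3 or compound 2 to compound 4, as all three stand at the same limit: the limit of > 10000 nM in this assay, at which 3 of the 4 values shown sit.

The compounds shown leave open whether phenyl to 4-methoxyphenyl changes the read-out at all.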